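From isopropyl to cyclopentylmethyl on an aromatic nitrogen

The compounds below may be only part of what the source reports. "The series", "measured", "known", "first", "only" and "open" are said of these compounds alone.

In a functional assay on HL-60 cells (Homo sapiens) for inhibition (on this read-out higher numbers stand for weaker inhibition and lower numbers for stronger inhibition), compound 1 `COc1ccc(-c2cc(O)nnc2-c2ccc(OC)cc2)cc1` gives 31600 nM and compound 2 `CCn1nc(-c2ccc(OC)cc2)c(-c2ccc(OC)cc2)cc1=O` gives 610 nM. Compound 3 `COc1ccc(-c2cc(=O)n(C(C)C)nc2-c2ccc(OC)cc2)cc1` lies between them at 1320 nM, the middle of the three numbers. Compound 4 `COc1ccc(-c2cc(=O)n(CC3CCCC3)nc2-c2ccc(OC)cc2)cc1` has cyclopentylmethyl in place of isopropyl on an aromatic nitrogen. Within the data shown here, only one measured step bears on this group, a 2.2-fold higher number from compound 2 to compound 3 (0.34 log units; beyond the scatter), and it is modest. It comes from a much smaller change, so it gives only a weak guide to direction. In this assay the expected change is again modest, leaning lower: a 2.2-fold lower number from compound 3 to compound 4 (0.34 log units; beyond the scatter). Compound 4 is estimated at 600 nM, with an expected range of 150 nM to 2400 nM.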

Compound 4, half-maximal inhibitory concentration: 110 nM
Compound 4: middle estimate off by 5.5-fold (0.74 log units), on the high side, and the stated range ends above it.
By their numbers in this assay, from the lowest: compound 4; then compound 2; then compound 3; then compound 1.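

On this nitrogen, the change to cyclopentylmethyl gives a far larger gain in inhibition than the earlier step suggested, with a 12-fold lower number from compound 3 to compound 4 (1.08 log units; beyond the scatter), and the ring-bearing compound also improves on the smaller chain, with a 5.5-fold lower number from compound 2 to compound 4 (0.74 log units; beyond the scatter). The number therefore does not simply follow the size of this group: compound 3 goes against any steady fall, since adding a methyl to compound 2 raised the number. Nothing measured here explains the difference. Going by these compounds, it remains open whether the ring alone matters, and how a cyclohexylmethyl or benzyl group would behave at this nitrogen.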